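A cytotoxicity series on bovine endothelial cells

The source may hold more compounds than are shown below. What is called first, only, known or untested is meant among the compounds shown, and "the series" means these compounds.

The study measures how strongly two compounds and one yet unmeasured analogue harm cells in an ADME assay on BAEC cells (Bos taurus) for cytotoxicity, read by MTT assay, with a stated time of 2 days; a lower number here means a stronger inhibitor, a higher number a weaker inhibitor. Compound 1, `OCc1cc(Br)cc(Br)c1O`, is the smaller member of the set. In this assay compound 1 gives > 35000 nM, which is a limit of the measurement and not a number. Compound 2, `COc1c(Br)cc(/C=C2\N=C(c3ccccc3)OC2=O)c(OCc2ccccc2)c1Br`, carries the shared core with a benzyl ether. In this assay, within the data shown here, compound 2 gives 921000 nM, the only actual number recorded in this set. The entry of compound 1 is a limit (the limit of > 35000 nM in this assay, at which 1 of the 2 values shown sits).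

Compound 3, `COc1c(Br)cc(/C=C2\N=C(c3ccccc3)OC2=O)c(OC(=O)c2ccc(N(C)C)cc2)c1Br`, differs from compound 2 in a single place: (4-(dimethylamino)phenyl)carbonyl in place of benzyl on an oxygen on an aromatic ring. Among the measured compounds shown here, no step between two measured compounds exists here to show how such a change affects cell survival, so the expectation rests on compound 2 alone. With so weak a starting point, the step from compound 2 to compound 3 is expected to be small, a 1.5-fold lower number from compound 2 to compound 3 (0.19 log units; within the scatter), and not beyond the usual scatter. Compound 3 is therefore estimated at 600000 nM in this assay, with a likely range from 150000 nM to 2000000 nM.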

Compound 3, half-maximal inhibitory concentration: 83000 nM
Beside the measured number, compound 3's estimate is 7.2-fold (0.86 log units) above it; the whole stated range lies above it.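

On the oxygen on an aromatic ring, the swap of benzyl for (4-(dimethylamino)phenyl)carbonyl gives an 11-fold lower number from compound 2 to compound 3 (1.05 log units; beyond the scatter) in this assay. Among these compounds, this is the first single change in the set that can be read, and it shows that this position is not indifferent: what sits on that oxygen can move the number well beyond the scatter, towards stronger harm to the cells. Nothing in the data shown accounts for the size of this step.

The change also alters two things at once, since the entering group brings both a carbonyl joined to the oxygen and a dimethylamino group on the aromatic ring, so a single step cannot say which of them goes with the lower number; a plain benzoyl group or a 4-(dimethylamino)benzyl group on the same oxygen would separate the two. From the compounds shown here alone, whether a small acetyl group, a longer alkyl chain or a free hydroxyl at this place would follow the same direction also remains open.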